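The compounds below may be only part of what the source reports. "The series", "measured", "known", "first", "only" and "open" are said of these compounds alone.

Measured so far in an assay on CHO cells for displacement of a labelled ligand from prostaglandin D2 receptor 2 (Homo sapiens), read by scintillation counting; on this read-out higher numbers stand for weaker inhibition and lower numbers for stronger inhibition:
compound 1, `COCCN(C)S(=O)(=O)c1ccc(C)c(C#Cc2cc(Cl)ccc2OCC(=O)O)c1`, giving 4.1 nM;
compound 2, `CNS(=O)(=O)c1ccc(C)c(C#Cc2cc(Cl)ccc2OCC(=O)O)c1`, giving 10 nM.

Compound 2 stands at the higher of the two numbers in this assay, the other being compound 1. Among the compounds with values here, the only measured step, a 2.4-fold higher number from compound 1 to compound 2 (0.39 log units; beyond the scatter), is a modest loss when hydrogen replaces 2-methoxyethyl on the sulfonamide nitrogen.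

Compound 3, `COCCNS(=O)(=O)c1ccc(C)c(C#Cc2cc(Cl)ccc2OCC(=O)O)c1`, is not yet measured. It differs from compound 2 in this way: methoxymethyl in place of hydrogen on a saturated chain carbon bound to a sulfonamide nitrogen. Cut one bond further out, this reads methylsulfamoyl to (2-methoxyethyl)sulfamoyl; thus the 2-methoxyethyl group present in compound 1 returns, though on the carbon of the methyl rather than as a second substituent on the nitrogen. The step from compound 1 to compound 2 is the one that bears on this change, and it suggests a modest gain. Compound 3 is therefore expected to give a somewhat lower number, a 1.8-fold lower number from compound 2 to compound 3 (0.26 log units; within the scatter), landing at an estimated 5.5 nM with a range of 2.5 nM to 12 nM.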

Compound 3, inhibition constant: 3.6 nM
Beside the measured number, compound 3's estimate is 1.5-fold (0.18 log units) above it; low and high end bracket the measured number.
By their numbers in this assay, from the lowest: compounds 3 and 1 (each within the scatter of the next); then compound 2.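

In this assay, adding methoxymethyl to the methyl on the sulfonamide nitrogen of compound 2 gives a gain beyond the scatter (a 2.8-fold lower number from compound 2 to compound 3 (0.44 log units; beyond the scatter)), so the 2-methoxyethyl group brings this gain without a second substituent on that nitrogen. Hydrogen in place of methyl on the same nitrogen gives no readable change (a 1.1-fold lower number from compound 1 to compound 3 (0.06 log units; within the scatter)), so among these three compounds the lower numbers go with 2-methoxyethyl, while the methyl on the nitrogen of compound 1 makes no difference that can be read. Nothing shown gives a reason for either step.

Open, from the compounds shown here alone, is whether the ether oxygen matters, which an all-carbon propyl chain would test, and whether a 2-hydroxyethyl group or a longer chain keeps the number. Also open, going by these compounds, is how a terminal amine on this chain would read.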